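The compounds below may be only part of what the source reports. "The series", "measured", "known", "first", "only" and "open" are said of these compounds alone.

Measured so far:
Compound 1, `CN1CCN(CCCN(C[C@H]2Cc3ccccc3CN2)[C@H]2CCCc3cccnc32)CC1`: 72%
Compound 2, `CC(C)N1CCN(CCCN(C[C@H]2Cc3ccccc3CN2)[C@H]2CCCc3cccnc32)CC1`: 46%
Compound 3, `NC(=O)N1CCN(CCCN(C[C@H]2Cc3ccccc3CN2)[C@H]2CCCc3cccnc32)CC1`: 79%

The measurement behind these numbers is an ADME assay on microsomes from liver (Homo sapiens) for metabolic stability, read by LC-MS, with a stated time of 10 min, tested at 0.5 uM; a higher number here means that more of the compound is left, a lower number that less of the compound is left. Compound 1 sits second highest of the three; compound 3 gives 79%, and the step of a number 7 percentage points higher from compound 1 to compound 3 (within the scatter) lies within the scatter, so the two cannot be ordered. Compound 2 is clearly lower, by a number 26 percentage points lower from compound 1 to compound 2 (beyond the scatter), and compound 2 to compound 3 shows a number 33 percentage points higher from compound 2 to compound 3 (beyond the scatter).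

Compound 4, `CN1CCN(CCCN(C[C@H]2Cc3ccccc3CN2C)[C@H]2CCCc3cccnc32)CC1`, differs from compound 1 by methyl in place of hydrogen on an amine nitrogen in a ring. For the measured compounds named here, no measured step puts a methyl in place of hydrogen, and the measured steps all change a different amine nitrogen in a ring of the shared core. The nearest guide is the step from compound 1 to compound 2, where a larger alkyl group on a ring amine nitrogen went with a modest drop, a number 26 percentage points lower from compound 1 to compound 2 (beyond the scatter). A small decrease in this assay is therefore expected, though it may stay within the scatter. For compound 4 the expected value is 60%, with a range of 40% to 80%. This expected step, a number 12 percentage points lower from compound 1 to compound 4 (beyond the scatter), rests on that single related comparison.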

Compound 4, percent of the compound remaining: 60%
Beside the measured number, compound 4's estimate shows no gap at the digits printed; measured number inside the range.
By their numbers in this assay, from the lowest: compound 2; then compound 4; then compounds 1 and 3 (each within the scatter of the next).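

For the compounds shown here, until now every change sat on a different amine nitrogen of the shared core, so this is the first reading at the amine nitrogen of the six-membered non-aromatic ring that is part of a fused or bridged system of two rings. In this assay methyl in place of hydrogen at this nitrogen gives a number 12 percentage points lower from compound 1 to compound 4 (beyond the scatter) and so shows that the position responds to the addition of a single carbon. No measured evidence explains this step.

With only hydrogen and methyl shown at this nitrogen, it remains open whether a larger group such as ethyl would take the number further in the same direction. Going by these compounds, it also remains open whether an acetyl group, which places a carbonyl on this nitrogen, would behave like methyl or differently.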